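A few compounds are considered here, and "the series" means these few. Any claim that something is new, unique, unknown or untested is made for them only; others in the source may bear on it.

Compound 3 `CN(C)c1ccc(C2CC(c3ccc(-n4cncn4)cc3)=NN2C(=O)/C=C/c2ccccc2)cc1` sits at the bottom of the three numbers in hand: in a functional assay on HCC1806 cells (Homo sapiens) for inhibition, read by sulforhodamine B assay, tested at 10 uM (on this read-out higher numbers stand for more inhibition at the one concentration tested (going by the name of the read-out) and lower numbers for less inhibition), compound 3 gives -3.7%, while compound 2 `CC(=O)N1N=C(c2ccc(-n3cncn3)cc2)CC1c1ccc(N(C)C)cc1` gives 11% and compound 1 `CN1CCN(c2ccc(C3=NN(C(=O)/C=C/c4ccccc4)C(c4ccc(N(C)C)cc4)C3)cc2)CC1` gives 71%. Both measured steps lead into compound 3. The exchange of the group on the aromatic carbon, a number 74.7 percentage points lower from compound 1 to compound 3 (beyond the scatter), makes up most of the gap; the exchange on the carbonyl carbon, a number 14.7 percentage points lower from compound 2 to compound 3 (beyond the scatter), is smaller. Compound 4 `CN(C)c1ccc(C2CC(c3ccc(-n4cncn4)cc3)=NN2S(=O)(=O)c2ccc(C#N)cc2)cc1` keeps the 4-(1H-1,2,4-triazol-1-yl)phenyl group of compound 3 and alters only the group on the ring nitrogen: (4-cyanophenyl)sulfonyl in place of (2-phenylethenyl)carbonyl on an amine nitrogen in a ring. Among the measured compounds shown here, only the step from compound 2 to compound 3 touches this position, and it was modest; no measured pair shows a sulfonyl there, so the size of such a change is unknown. The triazolyl group that weighed so heavily in a number 74.7 percentage points lower from compound 1 to compound 3 (beyond the scatter) remains, and compound 4 is therefore expected to stay low in this assay, with a step of a number 11.7 percentage points higher from compound 3 to compound 4 (beyond the scatter) that may not clear the scatter. The estimate for compound 4 is 8%, within -15% to 35%.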

Compound 4, a percentage reported as inhibition, at one concentration (the size of the read-out at that concentration, not a potency): 33.1%
The estimate for compound 4 lay 25.1 percentage points below the measured number, and the stated range covers the measured number.
By their numbers in this assay, from the lowest: compound 3; then compound 2; then compound 4; then compound 1.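

With the 4-(1H-1,2,4-triazol-1-yl)phenyl group held fixed, the group on the amine nitrogen in a ring proves able to move the read-out substantially in this assay: (4-cyanophenyl)sulfonyl in place of (2-phenylethenyl)carbonyl gives a number 36.8 percentage points higher from compound 3 to compound 4 (beyond the scatter). The same entering group in place of acetyl gives a number 22.1 percentage points higher from compound 2 to compound 4 (beyond the scatter), so among these three groups on this nitrogen, the sulfonyl-linked one gives the highest number, and the triazolyl group does not by itself hold the number low. No supporting data bear on the reason for this change.

The compounds shown do not separate the contribution of the sulfonyl link from that of the nitrile; a plain benzenesulfonyl or a methanesulfonyl group would address this. As far as these compounds go, it also remains open whether (4-cyanophenyl)sulfonyl gives a similar step alongside the 4-methylpiperazin-1-yl group.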